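Compound 3 to compound 4: a larger group on the amide

This account rests on a few compounds, and the source may have more. Where it says the series, first, only, none or still open, it means among the compounds named here.

In a functional assay on blood (Homo sapiens), with a stated time of 60 min, in the presence of a further agent that is not named here (on this read-out higher numbers stand for an effect only at larger amounts of compound and lower numbers for an effect already at smaller amounts), compound 1 (`O=S(=O)(c1ccc(Oc2ccc(OC(F)(F)F)cc2)cc1)C1CCC2(CCNCC2)C1`) gives > 15000 nM, which is a limit. Compound 3 (`O=C(Nc1ccccc1O)C1(S(=O)(=O)c2ccc(Oc3ccc(OC(F)(F)F)cc3)cc2)CCC2(CCNCC2)C1`) gives > 15000 nM, also a limit, and so stands at the limit of > 15000 nM in this assay, at which 2 of the 3 values shown sit. For the measured compounds named here, compound 2 (`O=C1CN(C(=O)C2(S(=O)(=O)c3ccc(Oc4ccc(OC(F)(F)F)cc4)cc3)CCC3(CCNCC3)C2)CCN1`) gives the only actual number, 7500 nM.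

Compound 4 (`Nc1ccc(-c2cccs2)cc1NC(=O)C1(S(=O)(=O)c2ccc(Oc3ccc(OC(F)(F)F)cc3)cc2)CCC2(CCNCC2)C1`) carries 2-amino-5-(thiophen-2-yl)phenyl in place of 2-hydroxyphenyl on an amide-type nitrogen. Going by the values given here, two measured steps bear on this change: an at least 2.0-fold higher number from compound 2 to compound 3 (0.30 log units; that floor lies within the scatter), and a step that the two limits leave unreadable from compound 1 to compound 3. Among the compounds with values here, neither measures a change of this aryl group alone, so no step clearly beyond the scatter is expected. The expected change, toward a slightly lower number, is an at least 1.6-fold lower number from compound 3 to compound 4 (0.22 log units; that floor lies within the scatter). For compound 4 the estimated value is 9000 nM, with an expected range of 2500 nM to 15000 nM.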

Compound 4, half-maximal effective concentration: 900 nM
Estimate against measurement, compound 4: 10-fold (1.00 log units) above; the whole stated range lies above it.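

In this assay, putting 2-amino-5-(thiophen-2-yl)phenyl in place of 2-hydroxyphenyl gives an at least 16-fold lower number from compound 3 to compound 4 (1.22 log units; beyond the scatter). This is the only step shown that lies beyond the scatter, so the group on this amide-type nitrogen can strongly shift the read-out. Compound 3 stands at a limit, so this size is only a floor: the limit of > 15000 nM in this assay, at which 2 of the 4 values shown sit.

The amino group and the thiophene ring enter together, and the compounds shown do not separate them. On these data alone, it remains open whether a 2-aminophenyl group without the thiophene ring would give a similar step.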